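Notes on a short series and a benzyloxycarbonyl analogue

The compounds below may be only part of what the source reports. "The series", "measured", "known", "first", "only" and "open" are said of these compounds alone.

compound 1 `O=C(Nc1ccc2nc(NC(=O)C3CCCCC3)sc2c1)c1c(Cl)cccc1Cl` — 0.015 ug/mL
compound 2 `CC(C)COC(=O)Nc1nc2ccc(NC(=O)c3c(Cl)cccc3Cl)cc2s1` — 0.0035 ug/mL

In a functional assay on WI-38 VA13 cells (Homo sapiens) for cytotoxicity (on this read-out lower numbers stand for an effect already at smaller amounts and higher numbers for an effect only at larger amounts of compound), compound 1 gives 0.015 ug/mL. Among the measured compounds shown here, compound 2 gives 0.0035 ug/mL, the lower of the two numbers; the only step so far, a 4.3-fold lower number from compound 1 to compound 2 (0.63 log units; beyond the scatter), replaced cyclohexyl with isobutoxy on the carbonyl carbon. Compound 3 `O=C(Nc1nc2ccc(NC(=O)c3c(Cl)cccc3Cl)cc2s1)OCc1ccccc1` carries phenyl in place of isopropyl on a saturated chain carbon bound to an oxygen next to a carbonyl group. For the measured compounds named here, no measured step touches the isobutyl end itself, so the cyclohexyl-to-isobutoxy step bears on it only loosely, and no step beyond the scatter is expected. For compound 3 the estimate is 0.004 ug/mL, range 0.0012 ug/mL to 0.013 ug/mL, meaning an expected 1.1-fold higher number from compound 2 to compound 3 (0.06 log units; within the scatter).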

Compound 3, half-maximal effective concentration: 0.018 ug/mL
Compound 3: middle estimate off by 4.5-fold (0.65 log units), on the low side; measured number above the stated range.
By their numbers in this assay, from the lowest: compound 2; then compounds 1 and 3 (each within the scatter of the next).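

At the saturated chain carbon bound to an oxygen next to a carbonyl group, phenyl in place of isopropyl is not a silent exchange in this assay (a 5.1-fold higher number from compound 2 to compound 3 (0.71 log units; beyond the scatter)). With benzyloxy in place of cyclohexyl on the carbonyl carbon, the step reads (a 1.2-fold higher number from compound 1 to compound 3 (0.08 log units; within the scatter)), so the oxygen link alone does not carry the low number of compound 2. No evidence on hand bears on this result.

Open, from the compounds shown here alone, is whether the aromatic ring or simply the larger end group matters; a cyclohexylmethoxy group would separate the two. Going by these compounds, how a longer straight chain would read here also stays open.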